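This account rests on a few compounds, and the source may have more. Where it says the series, first, only, none or still open, it means among the compounds named here.

Measured in an ADME assay on NHDF cells (Homo sapiens) for cytotoxicity, read by MTT assay, with a stated time of 72 h; a higher number here means a weaker inhibitor, a lower number a stronger inhibitor:
Compound 1 `COc1cccc(/C=C2\CCC/C(=C\c3ccc(Br)cc3)C2=O)c1OC` gives 21400 nM
Compound 2 `COc1cccc(/C=C2\CCC/C(=C\c3ccc(O)cc3)C2=O)c1OC` gives > 50000 nM (a limit)
Compound 3 `COc1cccc(/C=C2\CCC/C(=C\c3cccc(Cl)c3Cl)C2=O)c1OC` gives > 50000 nM (a limit)

Compound 3 has no number and stands at the limit of > 50000 nM in this assay, at which 2 of the 3 values shown sit.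

Compound 4 `COc1cccc(/C=C2\CCC/C(=C\c3ccc(O)c(Cl)c3)C2=O)c1OC` carries 3-chloro-4-hydroxyphenyl in place of 2,3-dichlorophenyl on a double-bonded chain carbon bound to a double-bonded ring carbon.

Two readable steps bear on this change, an at least 2.3-fold higher number from compound 1 to compound 2 (0.36 log units; beyond the scatter) and an at least 2.3-fold higher number from compound 1 to compound 3 (0.36 log units; beyond the scatter), and both lie beyond the scatter. The third, a step that the two limits leave unreadable from compound 2 to compound 3, gives no size. Compound 4 keeps the hydroxy of the first step, an at least 2.3-fold higher number from compound 1 to compound 2 (0.36 log units; beyond the scatter), so at most a modest move to a lower number is expected in this assay, and perhaps none that can be read. The expected change is an at least 1.4-fold lower number from compound 3 to compound 4 (0.15 log units; that floor lies within the scatter). Compound 4 is estimated at 35000 nM, with an expected range of 15000 nM to 60000 nM.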

Compound 4, half-maximal inhibitory concentration: 39500 nM
Compound 4: middle estimate off by 1.1-fold (0.05 log units), on the low side, and the stated range covers the measured number.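

In this assay, 3-chloro-4-hydroxyphenyl at this place gives a measured number, and its comparison with 4-bromophenyl shows a 1.8-fold higher number from compound 1 to compound 4 (0.27 log units; within the scatter). Chloro in place of hydrogen on an aromatic carbon gives an at least 1.2-fold lower number from compound 2 to compound 4 (0.10 log units; that floor lies within the scatter), and the change from 2,3-dichlorophenyl gives an at least 1.2-fold lower number from compound 3 to compound 4 (0.10 log units; that floor lies within the scatter). These last two steps are only floors, as each starts from a limit: the limit of > 50000 nM in this assay, at which 2 of the 4 values shown sit.

The compounds shown leave open how far the number moves when an amine or a carboxylic acid stands in place of the hydroxy. They also leave open whether a methoxy there would behave like the hydroxy.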